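A few compounds are considered here, and "the series" means these few. Any claim that something is new, unique, unknown or untested is made for them only; others in the source may bear on it.

- Compound 1 `COc1ccc(N2C(=O)COc3ccc(-c4cnc(OC)c(NS(=O)(=O)c5ccc(F)cc5)c4)cc32)cc1`: 18400 nM
- Compound 2 `COc1ncc(-c2ccc3c(c2)N(c2ccc(Cl)cc2)C(=O)CO3)cc1NS(=O)(=O)c1ccc(F)cc1`: 24100 nM

In a functional assay on A-375 cells (Homo sapiens) for antiproliferative activity, read by MTT assay, with a stated time of 72 h (on this read-out lower numbers stand for stronger inhibition and higher numbers for weaker inhibition), compound 2 at 24100 nM lies within the scatter of compound 1. Compound 3 `COc1ncc(-c2ccc3c(c2)N(C(C)C)C(=O)CO3)cc1NS(=O)(=O)c1ccc(F)cc1` carries isopropyl in place of 4-chlorophenyl on an amide-type nitrogen in a ring. Within the data shown here, the only measured step, a 1.3-fold higher number from compound 1 to compound 2 (0.12 log units; within the scatter), is chloro in place of methoxy on an aromatic carbon. It does not test the loss of that ring, so it is a weak guide, and no step beyond the scatter can be expected in either direction in this assay. The expected step is a 1.3-fold lower number from compound 2 to compound 3 (0.13 log units; within the scatter). For compound 3 the estimated value is 18000 nM, with an expected range of 5000 nM to 50000 nM.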

Compound 3, half-maximal inhibitory concentration: 9950 nM
Compound 3: the middle estimate sits 1.8-fold (0.26 log units) above what was measured; the measured number falls inside the stated range.
By their numbers in this assay, from the lowest: compounds 3, 1 and 2 (each within the scatter of the next, the first and the last beyond it).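

In this assay, isopropyl in place of 4-chlorophenyl on the amide-type nitrogen gives a 2.4-fold lower number from compound 2 to compound 3 (0.38 log units; beyond the scatter), showing that this position tolerates the loss of the aromatic ring. Against 4-methoxyphenyl, the same group gives a 1.8-fold lower number from compound 1 to compound 3 (0.27 log units; within the scatter), so the modest gain holds against only one of the two aryl groups. Nothing available explains the difference. The compounds shown leave open how methyl, a longer chain such as n-butyl, or a chain ending in an amine would behave on this nitrogen.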